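The compounds below may be only part of what the source reports. "The series", "measured", "known", "first", "only" and "open" are said of these compounds alone.

Compound 3, `Nc1ccccc1NC(=O)c1ccc(CSc2ccc(F)cc2)cc1`, belongs to a small set of three benzamides that share one core and differ only in the group attached to the sulfur. In a functional assay on SMMC-7721 cells (Homo sapiens) for inhibition, read by CCK-8 assay, with a stated time of 72 h, tested at 8 uM (on this read-out higher numbers stand for more inhibition of growth at the one concentration tested and lower numbers for less inhibition of growth), compound 3 gives 81.9%. Compound 2, `Cc1cc(C)cc(SCc2ccc(C(=O)Nc3ccccc3N)cc2)c1`, gives 85.1%, and the two lie close together: a number 3.2 percentage points lower from compound 2 to compound 3 (within the scatter). Compound 1, `Nc1ccccc1NC(=O)c1ccc(CSc2ccc(Br)cc2)cc1`, gives 25.3%, and both of its steps to the others are large: a number 59.8 percentage points higher from compound 1 to compound 2 (beyond the scatter), and a number 56.6 percentage points higher from compound 1 to compound 3 (beyond the scatter). Compound 3 thus stands second highest of the three numbers, separated from compound 2 by a gap within the scatter and from compound 1 by a large gap.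

Compound 4, `Nc1ccccc1NC(=O)c1ccc(CSCCc2ccccc2)cc1`, differs from compound 3 in one place: phenethyl in place of 4-fluorophenyl on a sulfur. Of the measured steps, the exchange of one aryl group on the sulfur for another bears most directly on this change. That exchange was small between compound 2 and compound 3, but large in both steps from compound 1, so the number on this position can swing widely. Nothing measured here covers a phenethyl group, so the expectation rests on a broad range. On these grounds compound 4 is expected to give 60% in this assay, within 25% to 88%, which is an expected step of a number 21.9 percentage points lower from compound 3 to compound 4 (beyond the scatter).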

Compound 4, percent growth inhibition at one concentration: 77.9%
Beside the measured number, compound 4's estimate is 17.9 percentage points below it; measured number inside the range.
By their numbers in this assay, from the lowest: compound 1; then compounds 4, 3 and 2 (each within the scatter of the next).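

The result shows that the group on the sulfur need not be an aryl group joined straight to it: phenethyl gives a number 4 percentage points lower from compound 3 to compound 4 (within the scatter) in this assay, and against the other high compound it gives a number 7.2 percentage points lower from compound 2 to compound 4 (within the scatter), so neither step separates phenethyl from the two aryl groups. Compound 1 now stands alone among the four, with a number 52.6 percentage points higher from compound 1 to compound 4 (beyond the scatter), and this step is of the same large kind as its steps to the other two compounds, so the position tolerates three quite different groups while 4-bromophenyl is the one exception in this small set. Nothing given here explains why 4-bromophenyl parts from the other three groups.

The compounds shown leave open whether a 4-chlorophenyl group on the sulfur would fall with compound 1 or with compound 3, which would tell whether the low number is tied to bromine or to something wider. They also leave open how a benzyl group, a longer chain such as phenylpropyl, or a ring carrying an amine or a carboxylic acid would read at this position.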